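Dimethylphenyl for Bromophenyl on the Ring Nitrogen

The source may hold more compounds than are shown below. What is called first, only, known or untested is meant among the compounds shown, and "the series" means these compounds.

Of the compounds shown here, two built on one shared core have been tested in a functional assay on MCF7 cells (Homo sapiens) for antiproliferative activity, read by MTT assay, with a stated time of 48 h; on this read-out higher numbers stand for weaker inhibition and lower numbers for stronger inhibition. Compound 1 `N#CC1=C(N)Oc2c(c3nc4ccccc4nc3c3ccccc23)C12C(=O)N(Cc1cnnn1-c1ccc(Cl)cc1)c1ccccc12` gives only a limit, > 50000 nM, which is not a number. For the measured compounds named here, compound 2 `N#CC1=C(N)Oc2c(c3nc4ccccc4nc3c3ccccc23)C12C(=O)N(Cc1cnnn1-c1ccc(Br)cc1)c1ccccc12` gives 36600 nM, the only real number measured so far in this assay. Going by the values given here, the one measured step, an at least 1.3-fold lower number from compound 1 to compound 2 (0.13 log units; that floor lies within the scatter), is a swap of one halogen for another, and its floor lies within the scatter, so it reveals no clear difference between the two compounds. Compound 3 `Cc1ccc(-n2nncc2CN2C(=O)C3(C(C#N)=C(N)Oc4c3c3nc5ccccc5nc3c3ccccc43)c3ccccc32)cc1C` is not yet measured; it differs from compound 2 by 3,4-dimethylphenyl in place of 4-bromophenyl on an aromatic nitrogen. Among the compounds with values here, no measured step covers such an exchange of a halogen for two methyl groups, so the data offer no ground to expect a shift beyond the scatter in this assay. Compound 3 is therefore expected near 35000 nM, within 10000 nM to 120000 nM. The step of a 1.0-fold lower number from compound 2 to compound 3 (0.02 log units; within the scatter) is expected to be small.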

Compound 3, half-maximal inhibitory concentration: > 50000 nM
Compound 3 ended at the assay's limit; the forecaster's own chance of this, stated with the estimate: 35%; at least 1.4-fold (0.15 log units) between middle value and limit.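

In this assay, the exchange of 4-bromophenyl for 3,4-dimethylphenyl on the aromatic nitrogen gives an at least 1.3-fold higher number from compound 2 to compound 3 (0.13 log units; that floor lies within the scatter), so a change from one halogen to two methyl groups shows no clear difference, just as the swap of halogens showed none. The step from compound 1 to compound 3 cannot be read, as both values are limits of the assay and not numbers. With three substituted phenyl groups now seen on this nitrogen, most of the series sits at a single ceiling: the limit of > 50000 nM in this assay, at which 2 of the 3 values shown sit.

From the compounds shown here alone, how far compound 1 and compound 3 lie beyond that limit remains unknown. Also open, going by these compounds, is whether a phenyl ring carrying a carboxylic acid or an amine, or a morpholine in place of the phenyl ring, would give a clearly lower number.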